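Aryl swap on the five-membered ring: compound 2 to compound 4

The source may report more compounds than this note shows. Statements on the series, on what has been measured and on what is new or still open speak of the compounds shown alone.

Measured so far in a functional assay on HL-60 cells (Homo sapiens) for cytotoxicity, read by MTT assay, with a stated time of 4 days; on this read-out lower numbers stand for stronger inhibition and higher numbers for weaker inhibition:
- compound 1 `C=C1C(=O)[C@]23C[C@@]1(O)CC[C@H]2c1ccc(OS(=O)(=O)c2ccc(C)cc2)c(C)c1[C@@H]3Cn1cc(-c2ccccn2)nn1` gives 1810 nM
- compound 2 `C=C1C(=O)[C@]23C[C@@]1(O)CC[C@H]2c1ccc(O)c(C)c1[C@@H]3Cn1cc(-c2ccccn2)nn1` gives 1970 nM
- compound 3 `Cc1c(O)ccc2c1[C@H](Cn1cc(-c3ccccn3)nn1)[C@@]13CC(=O)[C@@](C)(CC[C@@H]21)C3` gives > 20000 nM, which is a limit of this assay and not a number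

Compound 2 holds the highest of the two numbers in this assay; its nearest neighbour is compound 1, and the step of a 1.1-fold higher number from compound 1 to compound 2 (0.04 log units; within the scatter) is within the scatter. Compound 3 sits at the limit of > 20000 nM in this assay, at which 1 of the 3 values shown sits, so it contributes no number for comparison.

Compound 4 `C=C1C(=O)[C@]23C[C@@]1(O)CC[C@H]2c1ccc(O)c(C)c1[C@@H]3Cn1cc(-c2ccc(Br)cc2)nn1` is not yet measured. It differs from compound 2 in one place: 4-bromophenyl in place of pyridin-2-yl on an aromatic carbon. Within the data shown here, no measured step touches this position; the only step measured, from compound 1 to compound 2, concerns the oxygen on the aromatic ring and was within the scatter, so it gives no guide to the size of an aryl exchange on the five-membered ring. With no evidence for a change in either direction, compound 4 is expected to land close to compound 2 in this assay, the estimated step of a 1.0-fold higher number from compound 2 to compound 4 (0.01 log units; within the scatter) being none beyond the scatter. Compound 4 is therefore estimated at 2000 nM in this assay, with a range from 700 nM to 6000 nM that is kept wide for lack of any bearing step.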

Compound 4, half-maximal inhibitory concentration: 560 nM
The estimate for compound 4 lay 3.6-fold (0.55 log units) above the measured number, and the stated range ends above it.
By their numbers in this assay, from the lowest: compound 4; then compounds 1 and 2 (each within the scatter of the next). At a limit, above all of these: compound 3.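

In this assay, the aryl group on the five-membered ring with 3 nitrogen proves to be a position that responds: 4-bromophenyl in place of pyridin-2-yl gives a change beyond the scatter (a 3.5-fold lower number from compound 2 to compound 4 (0.55 log units; beyond the scatter)), unlike the change on the oxygen on the aromatic ring (a 1.1-fold higher number from compound 1 to compound 2 (0.04 log units; within the scatter)), which stays within it. This single exchange changes two things at once, since the pyridin-2-yl ring nitrogen leaves and a bromine enters on a ring of carbon only, and the step cannot assign the difference to either. Nothing measured on these compounds accounts for the step, so its cause stays unassigned.

Still open, going by these compounds, is which of the two changes carries the step: an unsubstituted phenyl would separate the loss of the ring nitrogen from the gain of the bromine, while chloro or methoxy in place of bromo on the phenyl ring would test whether bromine itself is needed. Also open, on these data alone, is whether an amine or a carboxylic acid on that phenyl ring would keep the lower number seen for compound 4 (560 nM).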